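Carbamoylcyclohexyl in place of hydroxycyclohexylmethyl on the aromatic amine

This account rests on a few compounds, and the source may have more. Where it says the series, first, only, none or still open, it means among the compounds named here.

Compound 3 `N#Cc1cnc(NCc2cnccc2C(F)(F)F)cc1NC[C@H]1CC[C@H](O)CC1` gives 2000 nM in an assay on isolated protein for inhibition of protein kinase C delta type (Homo sapiens), read by TR-FRET, with a stated time of 2 h (on this read-out lower numbers stand for stronger inhibition and higher numbers for weaker inhibition), the lowest of the two numbers shown. Compound 2 `N#Cc1cnc(NCc2cnccc2C(F)(F)F)cc1N[C@H]1CC[C@H](O)CC1` gives 6500 nM in this assay. Compound 1 `N#Cc1cnc(NCc2cnccc2C(F)(F)F)cc1N[C@H]1C[C@H](O)C1` reports only a limit in this assay, > 10000 nM, as noted in the limit of > 10000 nM in this assay, at which 1 of the 3 values shown sits. The measured steps are a 3.3-fold lower number from compound 2 to compound 3 (0.51 log units; beyond the scatter), an at least 5.0-fold lower number from compound 1 to compound 3 (0.69 log units; beyond the scatter) and an at least 1.5-fold lower number from compound 1 to compound 2 (0.18 log units; that floor lies within the scatter).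

Compound 4 `N#Cc1cnc(NCc2cnccc2C(F)(F)F)cc1N[C@H]1CC[C@@H](C(N)=O)CC1` differs from compound 3 in one place: 4-carbamoylcyclohexyl in place of (4-hydroxycyclohexyl)methyl on a nitrogen on an aromatic ring. The step from compound 2 to compound 3 bears on it most directly, since compound 4, like compound 2, places the ring directly on the nitrogen; that step was modest and beyond the scatter. Within the data shown here, no measured step covers the exchange of hydroxyl for carbamoyl, so its effect is unknown. Compound 4 is therefore expected to give a somewhat higher number than compound 3 in this assay, a step of a 2.3-fold higher number from compound 3 to compound 4 (0.35 log units; beyond the scatter). The estimate for compound 4 is 4500 nM, with a range from 1500 nM to 13000 nM.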

Compound 4, half-maximal inhibitory concentration: 400 nM
Compound 4: middle estimate off by 11-fold (1.05 log units), on the high side; measured number below the stated range.
By their numbers in this assay, from the lowest: compound 4; then compound 3; then compound 2. At a limit, above all of these: compound 1.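

In this assay, with the ring set directly on the nitrogen on an aromatic ring, 4-carbamoylcyclohexyl in place of 4-hydroxycyclohexyl gives a 16-fold lower number from compound 2 to compound 4 (1.21 log units; beyond the scatter), so the group carried by the ring moves the number strongly, and not only ring size or the extra carbon of (4-hydroxycyclohexyl)methyl. The extended hydroxyl group is also passed, with a 5.0-fold lower number from compound 3 to compound 4 (0.70 log units; beyond the scatter), so that extension is not needed for the lowest number shown. Against 3-hydroxycyclobutyl the change gives an at least 25-fold lower number from compound 1 to compound 4 (1.39 log units; beyond the scatter), a floor set by the limit of the assay for compound 1.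

The data shown give no reason for the gain. Going by these compounds, it remains open how a carboxylic acid, a methyl amide or a primary amine in place of the carbamoyl would read, and whether (4-carbamoylcyclohexyl)methyl would lower the number further.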